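Bulkier Ester Groups and Tolerance in Cultured Cells

The source may hold more compounds than are shown below. What is called first, only, known or untested is meant among the compounds shown, and "the series" means these compounds.

The compounds share one core, an adenine-bearing chain ending in an ester, and differ only in the group on an oxygen next to a carbonyl group. In a functional assay on HeLa cells (Homo sapiens) for cytotoxicity (a lower number here means that less compound is tolerated, a higher number that more compound is tolerated), compound 2 `COC(=O)C(O)Cn1cnc2c(N)ncnc21` reaches only the limit of the assay, > 400 ug/mL, so its true value is not a number. Compound 1 `CC(C)OC(=O)C(O)Cn1cnc2c(N)ncnc21` likewise stops at the limit, > 400 ug/mL. Compound 3 `Nc1ncnc2c1ncn2CC(O)C(=O)OC1CCCCC1` gives 100 ug/mL, a readable number. The step that the two limits leave unreadable from compound 1 to compound 2 cannot be sized, whereas an at least 4.0-fold lower number from compound 2 to compound 3 (0.60 log units; beyond the scatter) and an at least 4.0-fold lower number from compound 1 to compound 3 (0.60 log units; beyond the scatter) show that the cyclohexyl ester is tolerated less. The unmeasured compound 4 `CC(C)(C)OC(=O)C(O)Cn1cnc2c(N)ncnc21` differs from compound 2 by tert-butyl in place of methyl on an oxygen next to a carbonyl group. Tert-butyl is larger than methyl or isopropyl but, unlike cyclohexyl, brings no ring, so only part of the drop seen for compound 3 is expected. Compound 4 is therefore estimated to sit near 300 ug/mL, between 100 ug/mL and 800 ug/mL, with a good chance that this assay again reports only a limit. The expected step is an at least 1.3-fold lower number from compound 2 to compound 4 (0.12 log units; that floor lies within the scatter).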

Compound 4, minimum cytotoxic concentration: > 400 ug/mL
Compound 4 ended at the assay's limit (the forecaster's own chance of this, stated with the estimate: 55%); middle value at least 1.3-fold (0.12 log units) from the limit.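

In this assay compound 4 gives > 400 ug/mL, which is a limit of the assay and not a number. Tert-butyl on an oxygen next to a carbonyl group brings 4 heavy atoms and no ring, and replacing cyclohexyl with it gives an at least 4.0-fold higher number from compound 3 to compound 4 (0.60 log units; beyond the scatter), so among these esters, a larger group without a ring does not bring the lower number seen with cyclohexyl. The steps linking compound 1, compound 2 and compound 4 cannot be read, because all three stop at the same point: the limit of > 400 ug/mL in this assay, at which 3 of the 4 values shown sit.

Still open, on these data alone, is whether the lower number of compound 3 follows from its ring or from its carbon count, a question that a cyclopentyl ester or a longer chain such as n-hexyl could help separate. Also open, as far as these compounds go, is how far compound 1, compound 2 and compound 4 truly lie from one another.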